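This account rests on a few compounds, and the source may have more. Where it says the series, first, only, none or still open, it means among the compounds named here.

Measured compounds:
Compound 1, `CC(C)C(c1ccc(Cl)cc1)S(=O)(=O)Nc1nccs1` — in a functional assay on CHO cells for agonist activity at Free fatty acid receptor 2 (Homo sapiens), read by cAMP accumulation (on this read-out higher numbers stand for weaker inhibition and lower numbers for stronger inhibition), compound 1 gives > 100000 nM, which is a limit of the assay and not a number.
Compound 2, `CC(C)[C@H](C(=O)Nc1cnns1)c1ccc(Cl)cc1` — in this assay compound 2 gives 57000 nM.
Compound 3, `CC(C)(C)[C@H](C(=O)Nc1ncc(Br)s1)c1ccc(Cl)cc1` — in this assay compound 3 gives 700 nM.

Of the two numbers that were obtained, compound 3 has the lowest; compound 2 gives a far higher number, a gap well beyond the usual scatter. Compound 1 reaches only (the limit of > 100000 nM in this assay, at which 1 of the 3 values shown sits), so its value sets no number against which compound 3 can be placed.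

The untested compound is compound 4, `CC(C)(C)[C@H](C(=O)Nc1ncc(Cc2ccc(Cl)cc2)s1)c1ccc(Cl)cc1`. It differs from compound 3 in one place: 4-chlorobenzyl in place of bromo on an aromatic carbon. Among the compounds with values here, no pair among the measured compounds differs only in this way, so there is no measured step to draw on. The account here expects that the step of a 1.4-fold lower number from compound 3 to compound 4 (0.15 log units; within the scatter) stays within the usual scatter, with no clear direction. Compound 4 is therefore estimated at 500 nM, with a range from 100 nM to 3000 nM.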

Compound 4, half-maximal inhibitory concentration: 25000 nM
For compound 4 the middle estimate is 50-fold (1.70 log units) below the measured one; measured number outside the range, above it.
By their numbers in this assay, from the lowest: compound 3; then compound 4; then compound 2. At a limit, above all of these: compound 1.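

In this assay, 4-chlorobenzyl in place of bromo on the aromatic carbon next to the ring sulfur brings a 36-fold higher number from compound 3 to compound 4 (1.55 log units; beyond the scatter), which stands for weaker inhibition. The earlier compounds shown here offered no change at this position, and this step shows that the read-out responds strongly to the group placed there, with compound 4 giving 25000 nM. Nothing measured here gives a reason for the step.

The compounds shown leave open how a plain benzyl, a methyl or a carboxylic acid at this position would read. They therefore cannot separate the part played by the methylene link, the aromatic ring and the chlorine within the entering group.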